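Removing methoxycarbonyl from the nitro compound: cytotoxicity notes

This account rests on a few compounds, and the source may have more. Where it says the series, first, only, none or still open, it means among the compounds named here.

Measured in a toxicity assay on NIH3T3 cells (Mus musculus) for cytotoxicity, read by resazurin assay; a higher number here means that more compound is needed for the effect, a lower number that less compound is needed:
Compound 1 `c1ccc(-c2ccc(Cn3cncc3CNc3cccc(-c4ccccc4)c3)cc2)cc1`: 10000 nM
Compound 2 `COC(=O)c1ccc(NCc2cncn2Cc2ccccc2Cl)cc1-c1ccccc1`: 10000 nM
Compound 3 `COC(=O)c1ccc(NCc2cncn2Cc2ccc([N+](=O)[O-])cc2)cc1-c1ccccc1`: > 10000 nM (a limit)

Compound 3 has only a limit in this assay, at > 10000 nM. Compound 4 `O=[N+]([O-])c1ccc(Cn2cncc2CNc2cccc(-c3ccccc3)c2)cc1` has hydrogen in place of methoxycarbonyl on an aromatic carbon, ortho to a phenyl group (hydrogen in place of methoxycarbonyl on an aromatic carbon). For the measured compounds named here, the one measured step, a number no lower from compound 2 to compound 3 (the limit leaves the size open), lies at another place and leaves its size open. Compound 1 also lacks methoxycarbonyl and gives 10000 nM, the same value as compound 2 at 10000 nM. No change beyond the scatter is expected in this assay, and the expected step is a number no higher from compound 3 to compound 4 (the limit leaves the size open). Compound 4 is estimated at 10000 nM, with an expected range from 5000 nM to 20000 nM.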

Compound 4, half-maximal effective concentration: 10000 nM
For compound 4 middle estimate and measured number coincide at the digits printed, within the range that was stated.
By their numbers in this assay, from the lowest: compounds 1, 2 and 4 (each within the scatter of the next).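

For compound 3 in this assay the value is only a limit, so the size of the step for hydrogen in place of methoxycarbonyl cannot be read: the limit of > 10000 nM in this assay, at which 1 of the 4 values shown sits. With hydrogen on this aromatic carbon, that step is a number no higher from compound 3 to compound 4 (the limit leaves the size open), and nitro in place of phenyl shows no change at the digits printed from compound 1 to compound 4 (within the scatter) in this assay. The nitro group and the phenyl group therefore cannot be told apart here on this core.

As far as these compounds go, it remains open whether an amine or a carboxylic acid in place of methoxycarbonyl on this aromatic carbon would move the value in this assay. From the compounds shown here alone, the effect of methoxycarbonyl itself also stays open.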